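Swapping a Chloro-Methyl Ring for a Nitrile Ring

The compounds below may be only part of what the source reports. "The series", "measured", "known", "first", "only" and "open" are said of these compounds alone.

Compound 1 `Cc1ccc(NC(=O)Nc2ccccc2)cc1S(=O)(=O)N(C)C` gives 1400 nM in an assay on HEK293 cells for activation of Kir3.1/Kir3.2 (Homo sapiens), read by fluorescence and thallium flux, with a stated time of 4 min; a higher number here means that more compound is needed for the effect, a lower number that less compound is needed. Compound 2 `Cc1ccc(NC(=O)Nc2ccc(C)c(S(=O)(=O)N(C)C)c2)cc1Cl` gives 2900 nM in this assay, the highest of the two numbers. Within the data shown here, the only measured step is a 2.1-fold higher number from compound 1 to compound 2 (0.32 log units; beyond the scatter). Compound 3 `Cc1ccc(NC(=O)Nc2cccc(C#N)c2)cc1S(=O)(=O)N(C)C` differs from compound 2 by 3-cyanophenyl in place of 3-chloro-4-methylphenyl on an amide-type nitrogen. Going by these compounds, that single step is all that bears on the change, and it shows a substituted ring at this nitrogen giving a modestly higher number than phenyl; a 3-cyanophenyl ring itself is untested, so no step beyond the scatter is expected. Compound 3 is therefore estimated at 1800 nM in this assay, from 700 nM to 4500 nM. This expectation amounts to a 1.6-fold lower number from compound 2 to compound 3 (0.21 log units; within the scatter).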

Compound 3, half-maximal effective concentration: 3900 nM
The estimate for compound 3 lay 2.2-fold (0.34 log units) below the measured number, within the range that was stated.
By their numbers in this assay, from the lowest: compound 1; then compounds 2 and 3 (each within the scatter of the next).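

At this amide-type nitrogen, this assay does not separate 3-cyanophenyl from 3-chloro-4-methylphenyl (a 1.3-fold higher number from compound 2 to compound 3 (0.13 log units; within the scatter)). Cyano in place of hydrogen on an aromatic carbon gives a modest rise (a 2.8-fold higher number from compound 1 to compound 3 (0.44 log units; beyond the scatter)), so both substituted rings shown here need more compound than plain phenyl. Nothing available explains either step.

Two substituted rings cannot establish a general trend for this nitrogen. Going by these compounds, how a ring carrying an amine or a carboxylic acid would read here remains open, as does a longer alkyl chain in place of the ring.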